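This account rests on a few compounds, and the source may have more. Where it says the series, first, only, none or still open, it means among the compounds named here.

Working notes on the series in a functional assay on KB cells (Homo sapiens) for inhibition; on this read-out higher numbers stand for weaker inhibition and lower numbers for stronger inhibition.

Compound 1 `CNc1nc2cc(Cl)c(Cl)cc2n1COCCO` is one of the two compounds that reach only the upper limit of this assay; for compound 1 the read-out is given as > 100000 nM, a limit rather than a number. Within the data shown here, compound 2 `OCCOCn1c(SCc2ccccc2)nc2cc(Cl)c(Cl)cc21` carries benzylsulfanyl in place of methylamino on an aromatic carbon and is the single compound in the set with a measured number: in this assay compound 2 gives 55000 nM. The step of an at least 1.8-fold lower number from compound 1 to compound 2 (0.25 log units; that floor lies within the scatter) is therefore bounded on one side only, and its floor stays inside the usual scatter, so the change reads as modest at best; what is known of it rests on (the limit of > 100000 nM in this assay, at which 2 of the 3 values shown sit).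

Compound 3 `CNc1nc2c(Cl)c(Cl)ccc2n1COCCO` has the same atoms as compound 1 joined differently; the difference between the two cores is not broken down here. Compound 3 also returns only the limit, given in this assay as > 100000 nM.

Compound 4 `OCCOCn1c(SCc2ccccc2)nc2c(Cl)c(Cl)ccc21`, not yet measured, is built from compound 3 by benzylsulfanyl in place of methylamino on an aromatic carbon, the same change as that from compound 1 to compound 2, at the same place. With compound 3 sitting at the limit, the step from compound 3 to compound 4 is expected to be about an at least 1.4-fold lower number from compound 3 to compound 4 (0.15 log units; that floor lies within the scatter), in line with what the step from compound 1 to compound 2 showed. In this assay compound 4 is expected to give roughly 70000 nM, with an estimated range from 30000 nM to 150000 nM, and a fair chance that only a limit is reported.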

Compound 4, half-maximal inhibitory concentration: 35000 nM
Beside the measured number, compound 4's estimate is 2.0-fold (0.30 log units) above it; the range from low to high includes it.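

In this assay, benzylsulfanyl in place of methylamino on an aromatic carbon again goes with a lower number on the core of compound 3, giving an at least 2.8-fold lower number from compound 3 to compound 4 (0.45 log units; beyond the scatter). The change therefore points the same way on both cores, although only on the core of compound 3 does the floor of the step clear the scatter, and the two steps cannot be told apart: the same change on two cores in this assay, an at least 1.8-fold lower number (0.25 log units; that floor lies within the scatter) from compound 1 to compound 2 and an at least 2.8-fold lower number (0.45 log units; beyond the scatter) from compound 3 to compound 4; the limit leaves it open whether they differ. The true size of either step is not shown, and neither is any sign that the change adds the same amount on each core, since both starting compounds give only a limit: the limit of > 100000 nM in this assay, at which 2 of the 4 values shown sit.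

On these data alone, it remains open whether the lower number follows the sulfur atom, the six-membered aromatic ring of carbon only or the whole benzylsulfanyl group, which a methylsulfanyl or a benzylamino group at the same place could help to separate. As far as these compounds go, the part played by the (2-hydroxyethoxy)methyl group is also open, for example against a longer chain or a simple methyl group, as is whether any such group would carry the read-out well clear of the limit on both cores.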